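The source may report more compounds than this note shows. Statements on the series, on what has been measured and on what is new or still open speak of the compounds shown alone.

Measured so far in an assay on CHO cells for inhibition of metabotropic glutamate receptor 1 (Rattus norvegicus); a higher number here means a weaker inhibitor, a lower number a stronger inhibitor:
compound 1 `CCCOC(=O)c1[nH]c(COC(C)=O)c(C(=O)OC(C)(C)C)c1C` — 2700 nM
compound 2 `CCCOC(=O)c1[nH]c(C=O)c(C(=O)OC(C)(C)C)c1C` — 2000 nM
compound 3 `CCCOC(=O)c1[nH]cc(C(=O)OC(C)(C)C)c1C` — 75 nM

Compound 3 gives the lowest number of the three, and both gaps to it lie beyond the scatter: a 36-fold lower number from compound 1 to compound 3 (1.56 log units; beyond the scatter) and a 27-fold lower number from compound 2 to compound 3 (1.43 log units; beyond the scatter). The two substituted compounds sit close to each other, a 1.4-fold lower number from compound 1 to compound 2 (0.13 log units; within the scatter), so the single large separation in the set is between the compound with hydrogen at the site and the two that carry a group there.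

Next is compound 4, `CCCOC(=O)c1[nH]c(C(=O)OC)c(C(=O)OC(C)(C)C)c1C`, not yet measured. Relative to compound 3 the change is methoxycarbonyl in place of hydrogen on an aromatic carbon. The two measured steps that bear on this site both run the other way, from a substituted ring carbon to hydrogen, and both were large. A group with a carbonyl, as in compound 2, and a larger group with an ester, as in compound 1, both gave numbers far above compound 3. Methoxycarbonyl is again a carbonyl-bearing group at this site, so a large rise in this assay is expected, of a size near those two steps. Compound 4 is therefore expected at 1500 nM, range 400 nM to 6000 nM. The expected step is a 20-fold higher number from compound 3 to compound 4 (1.30 log units; beyond the scatter).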

Compound 4, half-maximal inhibitory concentration: 3200 nM
Compound 4: middle estimate off by 2.1-fold (0.33 log units), on the low side; measured number inside the range.
By their numbers in this assay, from the lowest: compound 3; then compounds 2, 1 and 4 (each within the scatter of the next).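

Methoxycarbonyl on the aromatic carbon next to the ring nitrogen gives in this assay the same kind of large rise as formyl and acetoxymethyl, with a 43-fold higher number from compound 3 to compound 4 (1.63 log units; beyond the scatter) as the step from the hydrogen compound, so the site has now gone against hydrogen with a third group. Within the substituted set the group's identity makes no readable difference: methoxy in place of hydrogen on the carbonyl carbon gives a 1.6-fold higher number from compound 2 to compound 4 (0.20 log units; within the scatter) and leaves the ester level with the aldehyde, while the exchange of acetoxymethyl for methoxycarbonyl gives a 1.2-fold higher number from compound 1 to compound 4 (0.07 log units; within the scatter) and again separates nothing, so in this assay these compounds read as one group, with compound 3 alone far below it. Nothing shown explains this split between hydrogen and the three groups.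

Still open, on these data alone, is whether any group other than hydrogen can be tolerated here, since a methyl, a fluorine, a nitrile, an aminomethyl or a carboxylic acid at this carbon could either stay near compound 3 or join the other three. A plain methyl or ethyl would show whether the rise needs an oxygen-bearing group at all.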